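Swapping Iodo for Chloro on a Shared Core

The compounds below may be only part of what the source reports. "The series", "measured", "known", "first", "only" and "open" are said of these compounds alone.

Values so far in a functional assay with Cavia porcellus as the target; on this read-out higher numbers stand for an effect only at larger amounts of compound and lower numbers for an effect already at smaller amounts
compound 1 `COC(=O)c1c(C)[nH]c(C)c1C(=O)c1ccccc1C(F)(F)F` gives 4840 nM
compound 2 `COC(=O)c1c(C)[nH]c(C)c1C(=O)c1ccccc1Br` gives 8950 nM
compound 3 `COC(=O)c1c(C)[nH]c(C)c1C(=O)c1ccccc1I` gives 5900 nM
compound 4 `COC(=O)c1c(C)[nH]c(C)c1C(=O)c1ccccc1Cl` awaits measurement

Compound 3 at 5900 nM sits inside the span of the other two values. Every step among the three stays within the scatter, so no order can be read from them.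

The change now in question is chloro in place of iodo on an aromatic carbon and amounts to chloro in place of iodo on an aromatic carbon of a six-membered aromatic ring of carbon only, ortho to a large group. The most similar measured swap puts iodo in place of bromo and gives a 1.5-fold lower number from compound 2 to compound 3 (0.18 log units; within the scatter) as its result. Putting bromo in place of trifluoromethyl gives a 1.8-fold higher number from compound 1 to compound 2 (0.27 log units; within the scatter) as its result, and putting iodo in place of trifluoromethyl gives a 1.2-fold higher number from compound 1 to compound 3 (0.09 log units; within the scatter) in the same way.

Among the measured compounds shown here, no measured compound carries chloro, so this is an extrapolation, but all three swaps stayed small. No shift beyond the scatter is expected, and no firm direction can be claimed. The step expected here is a 1.1-fold higher number from compound 3 to compound 4 (0.04 log units; within the scatter) and no more than that. For compound 4 the estimated value is 6500 nM with an expected range from 3000 nM to 13000 nM in this assay once it is tested.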

Compound 4, half-maximal effective concentration: 14000 nM
Compound 4: middle estimate off by 2.2-fold (0.33 log units), on the low side; the measured number lies above the stated range.
By their numbers in this assay, from the lowest: compounds 1, 3, 2 and 4 (each within the scatter of the next, the first and the last beyond it).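

The three earlier compounds could not be put in any order, but chloro now shows that the group at this aromatic carbon can move the number in this assay beyond the scatter, though only modestly. Chloro in place of iodo gives a step that passes the scatter (a 2.4-fold higher number from compound 3 to compound 4 (0.38 log units; beyond the scatter)), and so does chloro in place of trifluoromethyl (a 2.9-fold higher number from compound 1 to compound 4 (0.46 log units; beyond the scatter)), which means compound 4 needs a larger amount of compound for its effect than compound 1 or compound 3, whereas chloro in place of bromo stays inside it (a 1.6-fold higher number from compound 2 to compound 4 (0.19 log units; within the scatter)), so compound 2 and compound 4 cannot be told apart. Nothing available here explains why chloro behaves this way at this position.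

All four groups compared here are halogens or trifluoromethyl, so these compounds leave open whether a very different group at this carbon, such as an amine, a carboxylic acid or a longer chain, would shift the number further, and in which direction. They also leave open whether plain hydrogen at this carbon would fall within the same span of values.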